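Methyl for hydrogen on the linker amide nitrogen

A few compounds are considered here, and "the series" means these few. Any claim that something is new, unique, unknown or untested is made for them only; others in the source may bear on it.

Measured so far in an assay on HeLa cells for displacement of a labelled ligand from adenosine receptor A3 (Homo sapiens), read by fluorescence polarization, with a stated time of 30 min; on this read-out higher numbers stand for weaker inhibition and lower numbers for stronger inhibition:
Compound 1 `COc1ccc(-c2cc(NC(=O)CCC(=O)NCC(=O)NC3CCCCC3)nc(-c3ccc(OC)cc3)n2)cc1` gives 35100 nM in this assay.
Compound 2 `COc1ccc(-c2cc(NC(=O)CCC(=O)N(C)CC(=O)NCc3ccccc3)nc(-c3ccc(OC)cc3)n2)cc1` gives 9500 nM in this assay.
Compound 3 `COc1ccc(-c2cc(NC(=O)COCC(=O)NCC(=O)NC(C)(C)C)nc(-c3ccc(OC)cc3)n2)cc1` gives 11200 nM in this assay.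

Compound 3 holds the second highest of the three numbers. Its nearest neighbour is compound 2, whose value lies within the scatter of it, so no order between the two can be read. Compound 1 sits furthest away, with a higher number beyond the scatter. Compounds 1 and 2 differ from each other in more than one place, so their two values show only that the methylated, benzyl-bearing compound 2 reads lower than compound 1.

Compound 4 `COc1ccc(-c2cc(NC(=O)COCC(=O)N(C)CC(=O)NC(C)(C)C)nc(-c3ccc(OC)cc3)n2)cc1` is not yet measured. It differs from compound 3 in one place: methyl in place of hydrogen on an amide-type nitrogen. Going by the values given here, no pair of measured compounds isolates this change, so no step for it is known. The expectation is a modest move toward a lower number, or none beyond the scatter. For compound 4 the estimate is 8000 nM, within 3000 nM to 25000 nM, which is expected to correspond to a step of a 1.4-fold lower number from compound 3 to compound 4 (0.15 log units; within the scatter).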

Compound 4, inhibition constant: 7200 nM
Compound 4: the middle estimate sits 1.1-fold (0.05 log units) above what was measured, within the range that was stated.
By their numbers in this assay, from the lowest: compounds 4, 2 and 3 (each within the scatter of the next); then compound 1.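

In this assay, going by these compounds alone, this pair gives the first isolated reading of methyl in place of hydrogen on the amide-type nitrogen: a 1.6-fold lower number from compound 3 to compound 4 (0.19 log units; within the scatter). The step lies within the scatter, so no order can be read between the two compounds, and in this pair the amide hydrogen can be replaced by methyl without a change beyond the scatter. The earlier comparison of compound 1 and compound 2 could not show this, since those compounds differ in more than one place, and no measured evidence is available to explain the result.

As far as these compounds go, it remains open whether the same replacement gives a similar step in the frame of compound 1, where the linker and the end group differ. Also open, from the compounds shown here alone, is whether ethyl or a longer chain on this nitrogen would give a step beyond the scatter.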